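Swapping a six-membered ring chain for 2-methylcyclopropyl

A few compounds are considered here, and "the series" means these few. Any claim that something is new, unique, unknown or untested is made for them only; others in the source may bear on it.

Measured so far in a physicochemical assay for solubility; on this read-out higher numbers stand for higher solubility and lower numbers for lower solubility:
- compound 1 `CNC(=O)c1cc(C(=O)N[C@H]2[C@@H]3COC[C@@H]32)cc2c1OC[C@H]2c1cccnc1`: a limit, >= 104 ug/mL
- compound 2 `CNC(=O)c1cc(C(=O)NCCC[C@H]2OC[C@H](N)CO2)cc2c1OC[C@H]2c1ccccc1`: a limit, >= 153 ug/mL

Compound 2 sits at the limit (the limit of >= 153 ug/mL in this assay, at which 1 of the 2 values shown sits), so only a bound is known for it, not a number. The same holds for compound 1 at the limit of >= 104 ug/mL in this assay, at which 1 of the 2 values shown sits. Compound 3 `CNC(=O)c1cc(C(=O)N[C@H]2C[C@@H]2C)cc2c1OC[C@H]2c1ccccc1` differs from compound 2 by a group of 4 heavy atoms (4 carbon; one three-membered non-aromatic ring of carbon only) in place of a group of 10 heavy atoms (7 carbon, 1 nitrogen, 2 oxygen; one six-membered non-aromatic ring with 2 hetero atoms), on an amide-type nitrogen. Within the data shown here, no measured pair shows this kind of change, so the step is uncertain; a drop beyond the usual scatter in this assay is expected, with the step from an at least 5.1-fold lower number from compound 2 to compound 3 (0.70 log units; beyond the scatter). Compound 3 is therefore estimated at 30 ug/mL, likely between 8 ug/mL and 120 ug/mL.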

Compound 3, solubility: >= 76 ug/mL
Compound 3 ended at the assay's limit; the forecaster's own chance of this, stated with the estimate: 15%; at least 2.5-fold (0.40 log units) between middle value and limit.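

The step from compound 2 to compound 3 cannot be read, as both results are limits in this assay and not numbers. The compounds shown leave open whether 2-methylcyclopropyl on the amide-type nitrogen changes the read-out at all.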